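Moving a methoxy group around the benzyl ring

The compounds below may be only part of what the source reports. "The series", "measured", "known", "first", "only" and "open" are said of these compounds alone.

The compounds here share a core in which a long saturated chain links an indole bearing a fluorophenyl group to an amine; what changes is the group on the amine. Compound 1 is `COc1ccc(CNCCCCc2cn(-c3ccc(F)cc3)c3ccccc23)cc1`, and in an assay on membranes from brain for displacement of a labelled ligand from Sigma non-opioid intracellular receptor 1 (Cavia porcellus), read by radioligand binding (on this read-out lower numbers stand for stronger inhibition and higher numbers for weaker inhibition), compound 1 gives 129 nM. Compound 2, `COc1ccc2c(c1OC)CC[C@@H]2NCCCCc1cn(-c2ccc(F)cc2)c2ccccc12`, gives 122 nM in this assay, a number that sits within the usual scatter of that for compound 1. Compound 3, `CCN(CCCCc1cn(-c2ccc(F)cc2)c2ccccc12)C1CCc2c1ccc(OC)c2OC`, gives 59.2 nM, which lies beyond the scatter from compound 1, so of the three numbers compound 1 stands highest, with compound 3 showing the lowest.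

Compound 4 is `COc1cccc(CNCCCCc2cn(-c3ccc(F)cc3)c3ccccc23)c1`. It differs from compound 1 in one way: 3-methoxyphenyl in place of 4-methoxyphenyl on a saturated chain carbon bound to an amine nitrogen. Within the data shown here, the two compounds have the same atoms, joined differently, and no measured pair among the three shows what this kind of change does. With nothing of that sort to lean on, the step is expected to be small, in either direction, and most likely not beyond the scatter. The expected step from compound 1 to compound 4 is therefore a 1.2-fold lower number from compound 1 to compound 4 (0.07 log units; within the scatter). In this assay compound 4 is estimated at 110 nM, expected to lie between 40 nM and 300 nM.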

Compound 4, inhibition constant: 544 nM
Estimate against measurement, compound 4: 4.9-fold (0.69 log units) below; the whole stated range lies below it.
By their numbers in this assay, from the lowest: compound 3; then compounds 2 and 1 (each within the scatter of the next); then compound 4.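

Changing 4-methoxyphenyl to 3-methoxyphenyl on a saturated chain carbon bound to an amine nitrogen gives, in this assay, a 4.2-fold higher number from compound 1 to compound 4 (0.63 log units; beyond the scatter), a shift towards weaker inhibition. This shows that binding in this assay is sensitive to where the methoxy group sits on this ring, even though the two groups have the same heavy atoms, the same kind of aromatic ring and the same counts of hydrogen-bond donors and acceptors. Nothing available here accounts for the shift, so the reason for it remains unknown.

From the compounds shown here alone, what a plain benzyl group, a 4-hydroxybenzyl group or a 4-chlorobenzyl group would give in this place remains open, so it cannot yet be said whether 4-methoxyphenyl helps, 3-methoxyphenyl harms, or both are true compared with a ring that carries no methoxy group. Going by these compounds, it is also open whether moving a methoxy group would matter as much on the amine groups of compound 2 and compound 3, which carry two methoxy groups on a different ring arrangement.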